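This account rests on a few compounds, and the source may have more. Where it says the series, first, only, none or still open, it means among the compounds named here.

Measured compounds:
compound 1, `C#CCSc1nc(Nc2ccccc2Cl)c(C#N)c(-c2ccccc2)n1`, 24200 nM
compound 2, `N#Cc1c(Nc2cccc(C(F)(F)F)c2)nc(SCc2cn(Cc3ccccc3Cl)nn2)nc1-c1ccccc1`, 12600 nM

Of the compounds shown here, two have been measured in a functional assay on MCF7 cells (Homo sapiens) for inhibition, read by MTT assay, with a stated time of 72 h; a higher number here means a weaker inhibitor, a lower number a stronger inhibitor. Compound 1 gives 24200 nM, and compound 2 gives 12600 nM. Of these two numbers, compound 2 has the smaller one, yet its gap to compound 1 lies within the scatter of the method, so the two cannot be told apart on this evidence.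

Compound 3, `N#Cc1c(Nc2ccccc2F)nc(SCc2cn(Cc3ccccc3Cl)nn2)nc1-c1ccccc1`, has not yet been measured in this assay. It differs from compound 2 in one place: 2-fluorophenyl in place of 3-(trifluoromethyl)phenyl on a nitrogen on an aromatic ring. Within the data shown here, no pair of measured compounds differing in a single place is available, so the size of this step cannot be read from the data. The expectation for the step of a 1.2-fold higher number from compound 2 to compound 3 (0.08 log units; within the scatter) is therefore one of no change beyond the scatter. Compound 3 is estimated at 15000 nM, within a range from 5000 nM to 45000 nM.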

Compound 3, half-maximal inhibitory concentration: 8060 nM
Compound 3: the middle estimate sits 1.9-fold (0.27 log units) above what was measured; the range from low to high includes it.
By their numbers in this assay, from the lowest: compounds 3, 2 and 1 (each within the scatter of the next, the first and the last beyond it).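

In this assay, among these compounds, 2-fluorophenyl in place of 3-(trifluoromethyl)phenyl on a nitrogen on an aromatic ring gives a 1.6-fold lower number from compound 2 to compound 3 (0.19 log units; within the scatter), the only step here that can be read, as compound 1 differs from the others in more than one place. On this evidence, a group of 10 heavy atoms with three fluorines and one of 7 heavy atoms with a single fluorine cannot be told apart at this position. Nothing measured on these compounds speaks to why the step is this size.

The compounds shown leave open how a group of another kind on the phenyl ring, such as an amine or a carboxylic acid, would read here. They also leave open how an unsubstituted phenyl would compare with compound 2 and compound 3.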